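The compounds below may be only part of what the source reports. "The series", "measured", "known", "first", "only" and "open" are said of these compounds alone.

Compound 1, `Cc1nc(S(C)(=O)=O)ccc1Oc1ncnc(OC2CCN(C(=O)OC(C)(C)C#N)CC2)c1F`, in a functional assay on isolated protein for inhibition of Glucose-dependent insulinotropic receptor (Rattus norvegicus), read by HTRF and cAMP accumulation (on this read-out higher numbers stand for larger maximal responses and lower numbers for smaller maximal responses), gives 97%.
Compound 2, `Cc1nc(S(C)(=O)=O)ccc1Oc1ncnc(OC2CCN(C(=O)O[C@@H](C)CF)CC2)c1F`, gives 84%.
Compound 3, `Cc1nc(S(C)(=O)=O)ccc1Oc1ncnc(OC2CCN(C(=O)SC(C)C)CC2)c1F`, gives 81%.

All three share one core and differ only in the group attached to the carbonyl carbon that sits on the ring nitrogen. Compound 3 has the smallest of the three numbers, but the gap to compound 2 lies within the scatter (a number 3 percentage points lower from compound 2 to compound 3 (within the scatter)), so these two cannot be told apart; only compound 1 stands clearly apart from compound 3 (a number 16 percentage points lower from compound 1 to compound 3 (beyond the scatter)).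

Compound 4, `Cc1nc(S(C)(=O)=O)ccc1Oc1ncnc(OC2CCN(C(=O)C(C)(F)F)CC2)c1F`, differs from compound 3 in this way: 1,1-difluoroethyl in place of isopropylsulfanyl on a carbonyl carbon. It is the same position that was varied among the measured compounds. There, a number 13 percentage points lower from compound 1 to compound 2 (beyond the scatter) and a number 16 percentage points lower from compound 1 to compound 3 (beyond the scatter) were modest drops, while a number 3 percentage points lower from compound 2 to compound 3 (within the scatter) was within the scatter. Among the compounds with values here, no measured compound carries a 1,1-difluoroethyl group on this carbonyl carbon, so nothing speaks directly to this exchange. Given that the two exchanges away from compound 1 moved the maximal response only modestly, and the exchange between compound 2 and compound 3 not at all beyond the scatter, compound 4 is expected to stay close to compound 3, with a number 1 percentage points higher from compound 3 to compound 4 (within the scatter). The estimate for compound 4 is 82%, with a range from 68% to 96%.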

Compound 4, largest response reached (reported as efficacy), in percent of the reference or control that the assay uses: 87%
Estimate against measurement, compound 4: 5 percentage points below; low and high end bracket the measured number.
By their numbers in this assay, from the lowest: compounds 3, 2, 4 and 1 (each within the scatter of the next, the first and the last beyond it).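

In this assay, within the data shown here, putting 1,1-difluoroethyl in place of isopropylsulfanyl on the carbonyl carbon gives a step that stays inside the usual variation (a number 6 percentage points higher from compound 3 to compound 4 (within the scatter)), so this position also accepts a group joined through carbon, without the oxygen or sulfur link of the earlier compounds. Among these compounds, the two other comparisons are (a number 3 percentage points higher from compound 2 to compound 4 (within the scatter)) and (a number 10 percentage points lower from compound 1 to compound 4 (within the scatter)), which means that compound 4 cannot be told apart from any of the earlier compounds, even though compound 1 and compound 3 remain clearly apart from each other. Nothing available here gives a reason for this result.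

The compounds shown leave open what a plain ethyl group without fluorine, a longer chain such as propyl, or an amine on this carbonyl carbon would give, and so whether the two fluorines of the 1,1-difluoroethyl group play any part in the response. They also leave open whether the maximal response would hold up as well with any of these groups if the rest of the shared core were changed at the same time.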